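This account rests on a few compounds, and the source may have more. Where it says the series, first, only, none or still open, it means among the compounds named here.

Three thiosemicarbazide-linked aroyl hydrazides built on a shared core were tested in a functional assay on Hs 683 cells (Homo sapiens) for inhibition, read by colorimetric assay and MTT assay, with a stated time of 72 h; a lower number here means a stronger inhibitor, a higher number a weaker inhibitor. Compound 1 `COc1cc(C(=O)NNC(=S)Nc2csc(-c3ccc(C)cc3)c2)cc(OC)c1OC` gives 42000 nM in this assay. Compound 2 `COc1ccc(C(=O)NNC(=S)Nc2csc(-c3ccccc3)c2)cc1` gives 35000 nM in this assay, and compound 3 `COc1cc(OC)cc(C(=O)NNC(=S)Nc2csc(-c3ccc(C)cc3)c2)c1` gives 37000 nM in this assay. The three values lie within the usual scatter of one another, so none of the compounds can be set apart as more or less active than the others.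

One measured pair differs in a single place. From compound 3 to compound 1 the change is methoxy in place of hydrogen on an aromatic carbon, and the step is a 1.1-fold higher number from compound 3 to compound 1 (0.06 log units; within the scatter). Compound 2 and compound 3 differ in a larger part of the molecule, and the difference between their two cores is not broken down here.

Compound 4 `COc1ccc(C(=O)NNC(=S)Nc2csc(-c3ccccc3)c2)cc1OC` has not yet been measured in this assay. It arises from compound 2 by methoxy in place of hydrogen on an aromatic carbon. This is the same kind of change as that from compound 3 to compound 1, but the surroundings differ: in compound 1 the new methoxy sits ortho to two methoxy groups and para to a large group, whereas in compound 4 it sits ortho to a methoxy group and meta to a large group. Because the earlier step of a 1.1-fold higher number from compound 3 to compound 1 (0.06 log units; within the scatter) stayed within the scatter, the step for compound 4 is expected to be small as well, roughly a 1.1-fold higher number from compound 2 to compound 4 (0.04 log units; within the scatter). Compound 4 is therefore estimated to give about 38000 nM in this assay, most likely between 18000 nM and 80000 nM.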

Compound 4, half-maximal inhibitory concentration: 22000 nM
For compound 4 the middle estimate is 1.7-fold (0.24 log units) above the measured one; low and high end bracket the measured number.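

In this assay, putting methoxy in place of hydrogen on an aromatic carbon of compound 2, ortho to a methoxy group and meta to a large group, gives a 1.6-fold lower number from compound 2 to compound 4 (0.20 log units; within the scatter), so this step does not set the two compounds apart. Set beside the same change on the other core, this step shows no difference that exceeds what two such steps can scatter: the same change on two cores in this assay, a 1.1-fold higher number (0.06 log units; within the scatter) from compound 3 to compound 1 and a 1.6-fold lower number (0.20 log units; within the scatter) from compound 2 to compound 4, 1.8-fold (0.26 log units) apart, within the scatter of two such steps. This shows that the two pairs are compatible with the change carrying over from one core to the other, but it does not establish a shared effect of the change, as neither step by itself stands clear of the scatter, and two pairs in different surroundings are too few to support a rule for the series.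

The compounds shown leave open whether any group other than methoxy at this place, such as a hydroxyl, a chlorine atom, an amine or a carboxylic acid, would give a step that stands clear of the scatter. They also leave open whether such a step would carry over between the two cores in the same way.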